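The source may report more compounds than this note shows. Statements on the series, on what has been measured and on what is new or still open speak of the compounds shown alone.

Working notes on the series. Compound 1 `COc1ccc(/C=N/c2c(C)n(C)n(-c3ccccc3)c2=O)cc1` gives 977000000 nM in a functional assay on DLD-1 cells (Homo sapiens) for cytotoxicity, read by MTT assay, with a stated time of 72 h; on this read-out lower numbers stand for stronger inhibition and higher numbers for weaker inhibition. Compound 2 `Cc1c(/N=C/c2ccccc2Cl)c(=O)n(-c2ccccc2)n1C` gives 417000000 nM in the same read-out. For the measured compounds named here, the one measured step runs a 2.3-fold lower number from compound 1 to compound 2 (0.37 log units; beyond the scatter). On the two numbers available, compound 2 stands lowest; its nearest neighbour is compound 1, which sits higher by the same step.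

Compound 3 `COc1ccccc1/C=N/c1c(C)n(C)n(-c2ccccc2)c1=O` has not yet been measured. It differs from compound 2 as follows: methoxy in place of chloro on an aromatic carbon, ortho to a large group. Going by the values given here, only the step from compound 1 to compound 2 bears on this change, and only indirectly: there a methoxy-bearing ring was exchanged for a chloro-bearing ring, with the substituent moving to a different position at the same time, and the number fell modestly. Reversing chloro for methoxy while keeping the position is therefore expected to move the number back upward by a modest amount, if at all, roughly a 1.6-fold higher number from compound 2 to compound 3 (0.19 log units; within the scatter). Compound 3 is estimated at 650000000 nM, with a range from 250000000 nM to 1700000000 nM.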

Compound 3, half-maximal inhibitory concentration: 933000000 nM
Estimate against measurement, compound 3: 1.4-fold (0.16 log units) below; the range from low to high includes it.
By their numbers in this assay, from the lowest: compound 2; then compounds 3 and 1 (each within the scatter of the next).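

With the position held fixed, the exchange of chloro for methoxy on an aromatic carbon ortho to a large group gives, in this assay, a 2.2-fold higher number from compound 2 to compound 3 (0.35 log units; beyond the scatter); this isolates the group change, which the earlier step mixed with a change of place. The shift from 4-methoxyphenyl to 2-methoxyphenyl gives a 1.0-fold lower number from compound 1 to compound 3 (0.02 log units; within the scatter), so within this pair the place of the methoxy cannot be told apart in this read-out, and the earlier fall from compound 1 to compound 2 goes with the arrival of 2-chlorophenyl rather than with the shift of place alone. No supporting data bear on the origin of the difference between chloro and methoxy at this place.

Only chloro and methoxy are shown on this aromatic carbon, so it remains open whether the difference between them extends to other groups, such as a hydroxyl, an amine or a carboxylic acid. The compounds shown also leave open whether a chloro group on the 4-position of the ring would read differently from 2-chlorophenyl, and whether the gap between compound 2 and compound 3 holds in other cell lines.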